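Expected Effect of a Methoxycarbonyl Addition

The source may report more compounds than this note shows. Statements on the series, on what has been measured and on what is new or still open speak of the compounds shown alone.

Compound 1, `COC(=O)CC(=O)N1N=C(c2ccc(N3CCN(C)CC3)cc2)CC1c1ccc(N(C)C)cc1`: -0.4%
Compound 2, `CC(=O)N1N=C(c2ccc(-n3cncn3)cc2)CC1c1ccc(N(C)C)cc1`: 7.4%

Both measured compounds were tested in a functional assay on MDA-MB-231 cells (Homo sapiens) for inhibition, read by sulforhodamine B assay, tested at 10 uM; a higher number here means more inhibition at the concentration tested (going by the name of the read-out), a lower number less inhibition. In this assay compound 1 gives -0.4% and compound 2 gives 7.4%. Compound 2 has the higher of the two numbers, yet the gap to compound 1 lies within the scatter, so no order can be read from the two numbers; each number is low at the concentration tested. Compound 3, `COC(=O)CC(=O)N1N=C(c2ccc(-n3cncn3)cc2)CC1c1ccc(N(C)C)cc1`, has not yet been measured. It differs from compound 2 by methoxycarbonyl in place of hydrogen on a saturated chain carbon bound to a carbonyl carbon. Compound 1 already carries the same ((methoxycarbonyl)methyl)carbonyl chain on an otherwise related structure and shows a low number there. Going by the values given here, no measured pair isolates this change, so the step is expected to be small, none beyond the scatter, estimated as a number 3.4 percentage points lower from compound 2 to compound 3 (within the scatter). Compound 3 is therefore expected to give 4% in this assay, with a range from -8% to 16%.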

Compound 3, a percentage reported as inhibition, at one concentration (the size of the read-out at that concentration, not a potency): 6.8%
The estimate for compound 3 lay 2.8 percentage points below the measured number, within the range that was stated.
By their numbers in this assay, from the lowest: compounds 1, 3 and 2 (each within the scatter of the next).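

In this assay, methoxycarbonyl in place of hydrogen on a saturated chain carbon bound to a carbonyl carbon comes with a number 0.6 percentage points lower from compound 2 to compound 3 (within the scatter), so on this core the larger ((methoxycarbonyl)methyl)carbonyl chain gives no readable change from acetyl. With that chain held constant, 1H-1,2,4-triazol-1-yl in place of 4-methylpiperazin-1-yl on an aromatic carbon comes with a number 7.2 percentage points higher from compound 1 to compound 3 (within the scatter), so this swap gives no readable change either. Nothing available explains these numbers.

Going by these compounds alone, all three numbers are low at the concentration tested, so these compounds show only that neither change moves the number beyond the scatter. Going by these compounds, whether a carboxylic acid, an amine or a longer chain in place of the methoxycarbonyl would give a clearly higher number remains open.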